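This account rests on a few compounds, and the source may have more. Where it says the series, first, only, none or still open, it means among the compounds named here.

In a functional assay on L1210 cells (Mus musculus) for antiproliferative activity (on this read-out higher numbers stand for weaker inhibition and lower numbers for stronger inhibition), compound 1 `C/C(=C\Cc1cccc(C(N)=O)n1)CCC(=O)O` reads > 100000 nM, which is a limit of the assay. Compound 2 `C/C(=C\Cc1nc(C(N)=O)cs1)CCC(=O)O` gives > 100000 nM, again a limit. Compound 3 `C/C(=C\Cn1cnc2c(Cl)ncnc21)CCC(=O)O` stands at > 100000 nM, also a limit and not a number. Within the data shown here, the series so far therefore amounts to the limit of > 100000 nM in this assay, at which 3 of the 3 values shown sit. Compound 4 `C/C(=C\Cn1cnc2c(O)ncnc21)CCC(=O)O` differs from compound 3 in one place, with hydroxy in place of chloro on an aromatic carbon. Among the measured compounds shown here, no measured step is available as a guide, so no step beyond the scatter is expected in this assay, and the estimated change is a number no higher from compound 3 to compound 4 (the limit leaves the size open). Compound 4 is expected at about 100000 nM, with an estimated range of 30000 nM to 300000 nM.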

Compound 4, half-maximal inhibitory concentration: > 100000 nM
Compound 4 ended at the assay's limit; the forecaster's own chance of this, stated with the estimate: 85%; the middle value lies on the limit itself.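

No step from compound 3 to compound 4 can be read, since both stand at a limit and not at a number: the limit of > 100000 nM in this assay, at which 4 of the 4 values shown sit.

The compounds shown leave open how hydroxy and chloro actually compare in this assay, and what would bring any compound to a readable value.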